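The source may hold more compounds than are shown below. What is called first, only, known or untested is meant among the compounds shown, and "the series" means these compounds.

In an ADME assay on RAW264.7 cells (Mus musculus) for cytotoxicity, read by neutral red uptake, with a stated time of 24 h (on this read-out higher numbers stand for lower toxicity in this test and lower numbers for higher toxicity in this test), two compounds have been tested so far. For compound 1 `C=CCONC(=O)CN1C(=O)S/C(=C\CCCC)C1=O`, the result is a limit of the assay rather than a number: > 128000 nM. Among the measured compounds shown here, compound 2 `CCCC/C=C1\SC(=O)N(C(C)C(=O)NOCc2ccccc2)C1=O` gives 43900 nM, the only actual number available, so its position cannot yet be set against a second measured number. Compound 3 `C=CCONC(=O)C(C)N1C(=O)S/C(=C\CCCC)C1=O` has not yet been measured. It differs from compound 2 by a single change, (vinyl in place of phenyl on a saturated chain carbon bound to an oxygen), with vinyl in place of phenyl on a saturated chain carbon bound to an oxygen, which turns benzyloxy into allyloxy. For the measured compounds named here, no measured step shows the effect of this change directly. Compound 1 also carries allyloxy, and its limit of > 128000 nM points toward higher numbers. A modest rise is therefore expected, and the estimated step is a 2.1-fold higher number from compound 2 to compound 3 (0.31 log units; beyond the scatter). For compound 3, the estimated value is 90000 nM, within a range of 45000 nM to 150000 nM.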

Compound 3, half-maximal cytotoxic concentration: > 128000 nM
Compound 3: no number, only a limit (the forecaster's own chance of this, stated with the estimate: 40%); middle value at least 1.4-fold (0.15 log units) from the limit.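

In this assay, the change of phenyl to vinyl on a saturated chain carbon bound to an oxygen, which turns benzyloxy into allyloxy, now has a direct reading: an at least 2.9-fold higher number from compound 2 to compound 3 (0.46 log units; beyond the scatter). Among the compounds shown here, the earlier compounds offered no pair differing at this place alone, so this is the first sign that, with the rest of the molecule kept, allyloxy lies on the less toxic side of benzyloxy in this test. The step from compound 1 to compound 3, which adds methyl, cannot be read, and the full size of the benzyloxy to allyloxy step also stays unknown, because the read-out ends at a limit: the limit of > 128000 nM in this assay, at which 2 of the 3 values shown sit.

The compounds shown leave open how a longer chain in place of allyl, or an amine or a carboxylic acid carried on it, would read in this assay. Also open, from the compounds shown here alone, is how benzyloxy reads with hydrogen in place of methyl on the saturated chain carbon.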